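The source may report more compounds than this note shows. Statements on the series, on what has been measured and on what is new or still open speak of the compounds shown alone.

Compound 1, `CC(C)c1ccc2c(c1)[n+]([O-])c(NCCN(C)C)n[n+]2[O-]`, gives 42000000 nM in a physicochemical assay for solubility, in the presence of a further agent that is not named here; on this read-out higher numbers stand for higher solubility and lower numbers for lower solubility.
Compound 2, `CN(C)CCNc1n[n+]([O-])c2ccc(C(C)(C)C)cc2[n+]1[O-]`, gives 38000000 nM in this assay.
Compound 3, `CCOc1ccc2c(c1)[n+]([O-])c(NCCN(C)C)n[n+]2[O-]`, reaches only the limit > 50000000 nM in this assay, so for compound 3 a floor and no number is known.

On the numbers shown, compound 3 sits at the limit of > 50000000 nM in this assay, at which 1 of the 3 values shown sits. The steps that lead there, an at least 1.1-fold higher number from compound 1 to compound 3 (0.07 log units; that floor lies within the scatter) and an at least 1.3-fold higher number from compound 2 to compound 3 (0.11 log units; that floor lies within the scatter), are floors that lie within the scatter, so compound 3 cannot be set apart from compound 1 or compound 2. Compound 4, `CN(C)CCNc1n[n+]([O-])c2ccc(OCC3CC3)cc2[n+]1[O-]`, differs from compound 3 by cyclopropyl in place of methyl on a saturated chain carbon bound to an oxygen on an aromatic ring. Of the measured steps, the one that most resembles an enlargement of a saturated chain is a 1.1-fold lower number from compound 1 to compound 2 (0.04 log units; within the scatter), and it stays within the scatter; the two steps onto compound 3 exchange a branched alkyl for ethoxy and also stay within the scatter. Compound 4 is therefore expected to show no step beyond the scatter, a number no higher from compound 3 to compound 4 (the limit leaves the size open), and likely to reach the same limit. Compound 4 is estimated at 50000000 nM, within 20000000 nM to 100000000 nM.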

Compound 4, solubility: > 55000000 nM
Compound 4 gave a limit, no number; the forecaster's own chance of this, stated with the estimate: 60%; middle value at least 1.1-fold (0.04 log units) away from the limit.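

In this assay compound 4, which carries cyclopropylmethoxy where compound 3 carries ethoxy, also gives a limit and not a number: the limit of > 55000000 nM in this assay, at which 1 of the 4 values shown sits. Compound 3 also stands at a limit, so the step from the one to the other cannot be read. Within the data shown here, what is new is that a saturated ring on this ether still leaves the read-out at a limit, yet the floors against the alkyl compounds, an at least 1.4-fold higher number from compound 2 to compound 4 (0.16 log units; that floor lies within the scatter) and an at least 1.3-fold higher number from compound 1 to compound 4 (0.11 log units; that floor lies within the scatter), set no compounds apart.

As far as these compounds go, the actual values of compound 3 and compound 4 in this assay stay open, and with them any difference between ethoxy and cyclopropylmethoxy. Also open, from the compounds shown here alone, is how an amine or a carboxylic acid on this aromatic carbon, or a longer chain on the oxygen, would read.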